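This account rests on a few compounds, and the source may have more. Where it says the series, first, only, none or still open, it means among the compounds named here.

Compound 1 `COCCOc1nc(N)nc2c1ncn2/C=C1/CC1(CO)CO` and compound 2 `CCCCCOc1nc(N)nc2c1ncn2/C=C1/CC1(CO)CO` share one core and differ only in the chain on its oxygen. In an ADME assay on BCBL1 cells (Homo sapiens) for cytotoxicity, with a stated time of 7 days (on this read-out higher numbers stand for lower toxicity in this test and lower numbers for higher toxicity in this test), compound 1 gives > 20000 nM, which is a limit of the assay and not a number. Compound 2 gives > 20000 nM, which is also a limit. Compound 2 therefore has no exact position, and the two compounds share one reading, (the limit of > 20000 nM in this assay, at which 2 of the 2 values shown sit).

Compound 3 `CC(C)Sc1nc(N)nc2c1ncn2/C=C1/CC1(CO)CO` brings a larger change, isopropylsulfanyl in place of pentyloxy on an aromatic carbon. Going by the values given here, the only measured step that bears on it is a step that the two limits leave unreadable from compound 1 to compound 2, and it offers no size or direction to carry over. No clear change is therefore expected in this assay, and another limit is the likeliest report. The expected change is a number no higher from compound 2 to compound 3 (the limit leaves the size open). For compound 3 the estimated value is 20000 nM, with an expected range from 7000 nM to 60000 nM.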

Compound 3, half-maximal cytotoxic concentration: > 20000 nM
Compound 3: no number, only a limit (the forecaster's own chance of this, stated with the estimate: 70%); the middle value lies on the limit itself.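

Going by these compounds alone, compound 3 also gives a limit of the assay and not a number in this assay, so no step among compound 1, compound 2 and compound 3 can be read: the limit of > 20000 nM in this assay, at which 3 of the 3 values shown sit. From the compounds shown here alone, whether these three groups on the shared core differ at all in toxicity in this test stays open, with no exact value for any of them.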